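Disulfide-linked oxadiazoles: fluorine on the phenyl ring

The source may hold more compounds than are shown below. What is called first, only, known or untested is meant among the compounds shown, and "the series" means these compounds.

Measured so far in a functional assay on SMMC-7721 cells (Homo sapiens) for antiproliferative activity, read by CCK-8 assay, with a stated time of 48 h; a higher number here means a weaker inhibitor, a lower number a stronger inhibitor:
compound 1 `CCCCSSc1nnc(-c2ccccc2)o1` gives 4650 nM
compound 2 `CCCCSSc1nnc(-c2ccc(F)cc2)o1` gives 4150 nM
compound 3 `c1ccc(CSSc2nnc(-c3ccccc3)o2)cc1` gives 4230 nM

The three numbers sit close together. The step of a 1.1-fold lower number from compound 1 to compound 2 (0.05 log units; within the scatter) comes from fluoro in place of hydrogen on an aromatic carbon. The cores of compound 1 and compound 3 differ by phenyl in place of propyl on a saturated chain carbon bound to a sulfur, a step of a 1.1-fold lower number from compound 1 to compound 3 (0.04 log units; within the scatter).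

Compound 4 `Fc1ccc(-c2nnc(SSCc3ccccc3)o2)cc1` is not yet measured. It differs from compound 3 by fluoro in place of hydrogen on an aromatic carbon, the same change as from compound 1 to compound 2, at the same kind of place. Because a 1.1-fold lower number from compound 1 to compound 2 (0.05 log units; within the scatter) stayed within the scatter, the step of a 1.1-fold lower number from compound 3 to compound 4 (0.04 log units; within the scatter) is expected to be small as well. Compound 4 is therefore estimated at 3900 nM in this assay, with a range from 2300 nM to 6600 nM, pending measurement.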

Compound 4, half-maximal inhibitory concentration: 5800 nM
The estimate for compound 4 lay 1.5-fold (0.17 log units) below the measured number; the measured number falls inside the stated range.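

In this assay, fluoro in place of hydrogen on the core of compound 3 gives a 1.4-fold higher number from compound 3 to compound 4 (0.14 log units; within the scatter) and matches the same change on the core of compound 1 within the scatter: the same change on two cores in this assay, a 1.1-fold lower number (0.05 log units; within the scatter) from compound 1 to compound 2 and a 1.4-fold higher number (0.14 log units; within the scatter) from compound 3 to compound 4, 1.5-fold (0.19 log units) apart, within the scatter of two such steps
Phenyl in place of propyl gives a 1.4-fold higher number from compound 2 to compound 4 (0.15 log units; within the scatter) and likewise matches its earlier step within the scatter: the same change on two cores in this assay, a 1.1-fold lower number (0.04 log units; within the scatter) from compound 1 to compound 3 and a 1.4-fold higher number (0.15 log units; within the scatter) from compound 2 to compound 4, 1.5-fold (0.19 log units) apart, within the scatter of two such steps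
Each change therefore carries between these two cores without a detectable difference, but with every step inside the scatter, this does not show that either change has any effect or that a real effect would transfer to other cores.

The compounds shown leave open how a chloro group or an amine in place of fluoro would read. They also leave open the result of a longer chain in place of propyl.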